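The source may hold more compounds than are shown below. What is called first, only, known or untested is meant among the compounds shown, and "the series" means these compounds.

Compound 1 `Cc1ccc(Nc2nc(SCc3cn(Cc4ccc(Cl)cc4)nn3)nc(-c3ccccc3)c2C#N)cc1`: > 64000 nM
Compound 2 `Cc1ccc(Nc2nc(SCc3cn(Cc4ccc(F)cc4)nn3)nc(-c3ccccc3)c2C#N)cc1`: 51100 nM
Compound 3 `Cc1ccc(Cn2cc(CSc3nc(Nc4ccccc4F)c(C#N)c(-c4ccccc4)n3)nn2)cc1`: > 64000 nM

The three compounds share one core and differ only at their two outer aromatic rings. In a functional assay on MCF7 cells (Homo sapiens) for inhibition, read by MTT assay, with a stated time of 72 h (a lower number here means a stronger inhibitor, a higher number a weaker inhibitor), compound 3 reaches no number but only a limit, > 64000 nM. Compound 1 likewise stands at a limit, > 64000 nM. Within the data shown here, compound 2 is the only one with a number, 51100 nM. Among the measured compounds shown here, the single step between measured neighbours, an at least 1.2-fold lower number from compound 1 to compound 2 (0.09 log units; that floor lies within the scatter), concerns fluoro in place of chloro and lies within the scatter.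

Compound 4 `Cc1ccc(Cn2cc(CSc3nc(Nc4ccc(C)cc4)c(C#N)c(-c4ccccc4)n3)nn2)cc1` differs from compound 3 by 4-methylphenyl in place of 2-fluorophenyl on a nitrogen on an aromatic ring. For the measured compounds named here, no measured step bears on this change; the step from compound 1 to compound 2 sits at the other outer ring. Compounds 1 and 2 already carry the 4-methylphenyl on that nitrogen, and the evidence is the limit of > 64000 nM in this assay, at which 2 of the 3 values shown sit. Compound 4 is therefore expected to give 70000 nM, with a range from 30000 nM to 160000 nM, and most probably only a limit. The expected step is a step that the limit leaves unreadable from compound 3 to compound 4, none beyond the scatter.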

Compound 4, half-maximal inhibitory concentration: > 64000 nM
Compound 4: a limit, no number; the forecaster's own chance of this, stated with the estimate: 60%; the middle value does not contradict the limit.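

In this assay compound 4 reaches only a limit, > 64000 nM, so 4-methylphenyl on a nitrogen on an aromatic ring brings no number where 2-fluorophenyl brought none either. The steps from compound 3 and from compound 1 to compound 4 join two limits and cannot be read. Among these compounds, the one readable step, an at least 1.2-fold higher number from compound 2 to compound 4 (0.09 log units; that floor lies within the scatter), concerns methyl in place of fluoro on an aromatic carbon at the other outer ring, and it establishes no change beyond the scatter.

Limits now make up most of this small set: the limit of > 64000 nM in this assay, at which 3 of the 4 values shown sit. Still open, on these data alone, is whether any other group on that nitrogen, such as a phenyl ring carrying a carboxylic acid or a dimethylamino group, would give a readable number at this position.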